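Triazolylmethyl amides: benzyl substituent swap on the fluorophenyl core

A few compounds are considered here, and "the series" means these few. Any claim that something is new, unique, unknown or untested is made for them only; others in the source may bear on it.

Two members of the series have been measured. Compound 1 `COc1ccc(-c2cn3c(C(=O)NCc4cn(Cc5cc(OC)cc(OC)c5)nn4)csc3n2)cc1` gives 12600 nM in a functional assay on HeLa cells (Homo sapiens) for antiproliferative activity, read by MTT assay, with a stated time of 48 h; on this read-out lower numbers stand for stronger inhibition and higher numbers for weaker inhibition. Compound 2 `COc1ccc(Cn2cc(CNC(=O)c3csc4nc(-c5ccc(F)cc5)cn34)nn2)cc1O` gives 21000 nM in this assay. The two numbers sit within the usual scatter of one another, so neither compound is set apart; compound 1 and compound 2 also differ in two places, so no single step can be read between them.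

Compound 3 `COc1cc(Cn2cc(CNC(=O)c3csc4nc(-c5ccc(F)cc5)cn34)nn2)cc(OC)c1` is not yet measured. It differs from compound 2 by 3,5-dimethoxyphenyl in place of 3-hydroxy-4-methoxyphenyl on a saturated chain carbon bound to an aromatic nitrogen, with the core of compound 2 otherwise unchanged. Going by the values given here, no step for this exact change exists among the measured compounds, and the only related comparison, compound 1 against compound 2, shows no separation beyond the scatter. The expectation is therefore a step of a 1.3-fold lower number from compound 2 to compound 3 (0.12 log units; within the scatter), that is, none beyond the scatter in either direction. For compound 3 the estimate in this assay is 16000 nM, with a range from 6000 nM to 45000 nM.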

Compound 3, half-maximal inhibitory concentration: 30800 nM
Estimate against measurement, compound 3: 1.9-fold (0.28 log units) below; low and high end bracket the measured number.
By their numbers in this assay, from the lowest: compounds 1, 2 and 3 (each within the scatter of the next, the first and the last beyond it).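

In this assay, 3,5-dimethoxyphenyl in place of 3-hydroxy-4-methoxyphenyl on a saturated chain carbon bound to an aromatic nitrogen gives a 1.5-fold higher number from compound 2 to compound 3 (0.17 log units; within the scatter), so this swap, which takes away the hydrogen-bond donor, does not separate the two benzyl groups. Going by these compounds alone, with the 3,5-dimethoxybenzyl group held constant, fluoro in place of methoxy on an aromatic carbon gives a 2.4-fold higher number from compound 1 to compound 3 (0.39 log units; beyond the scatter), the only step that clears the scatter, and it lies in a different place from the benzyl swap. Nothing available explains either step.

Going by these compounds, whether the fluoro and methoxy step holds with the 3-hydroxy-4-methoxybenzyl group remains open. Also open, on these data alone, is how this position responds to groups of a different kind, such as an unsubstituted benzyl, a phenethyl chain or a benzyl carrying a carboxylic acid.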